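A few compounds are considered here, and "the series" means these few. Any claim that something is new, unique, unknown or untested is made for them only; others in the source may bear on it.

In a functional assay on A549 cells (Homo sapiens) for antiproliferative activity, read by MTT assay, with a stated time of 24 h (a lower number here means a stronger inhibitor, a higher number a weaker inhibitor), the compounds built on the shared core of compound 1 `CNC(=O)c1ccccc1Oc1nc(Nc2ccc(C(F)(F)F)cc2)ncc1Br` are all weak. Compound 1 gives only a limit of the assay, > 50000 nM. Compound 2 `CNC(=O)c1ccccc1Oc1nc(Nc2ccccc2OC)ncc1Br` gives 40500 nM, the higher of the two numbers seen, and compound 3 `CNC(=O)c1ccccc1Oc1nc(Nc2cccc(C(F)(F)F)c2)ncc1Br` gives 28300 nM, so close to compound 2 that the two sit within the scatter of this assay. Compound 4 `CNC(=O)c1ccccc1Oc1nc(Nc2cccc(C(C)C)c2)ncc1Br` is not yet measured. It differs from compound 2 by 3-isopropylphenyl in place of 2-methoxyphenyl on a nitrogen on an aromatic ring. Going by the values given here, with no measured step of this kind to lean on, and with compound 3 giving 28300 nM, compound 4 is expected to stay in the same weak region, the step from compound 2 to compound 4 being estimated as a 1.4-fold lower number from compound 2 to compound 4 (0.13 log units; within the scatter), a change no larger than the scatter. Compound 4 is therefore expected to give about 30000 nM in this assay, most likely between 10000 nM and 90000 nM.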

Compound 4, half-maximal inhibitory concentration: 7140 nM
For compound 4 the middle estimate is 4.2-fold (0.62 log units) above the measured one; measured number below the stated range.
By their numbers in this assay, from the lowest: compound 4; then compounds 3 and 2 (each within the scatter of the next). At a limit, above all of these: compound 1.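

In this assay the group on a nitrogen on an aromatic ring proves able to move the number, which compound 2 and compound 3, within the scatter of each other, could not show: the change gives a 5.7-fold lower number from compound 2 to compound 4 (0.75 log units; beyond the scatter). Isopropyl in place of trifluoromethyl on an aromatic carbon, a change in one group alone, gives a 4.0-fold lower number from compound 3 to compound 4 (0.60 log units; beyond the scatter). Nothing measured here bears on the cause of these steps. Going by these compounds, whether a tert-butyl group, a longer alkyl chain or an amine on that aromatic carbon would lower the number further remains open.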